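An aryl swap on the amide of compound 3

A few compounds are considered here, and "the series" means these few. Any claim that something is new, unique, unknown or untested is made for them only; others in the source may bear on it.

In a functional assay on A549 cells (Homo sapiens) for inhibition, read by CCK-8 assay, with a stated time of 72 h, tested at 10 uM (a higher number here means more inhibition of growth at the concentration tested, a lower number less inhibition of growth), compound 3 (`CN(C)C(=O)c1cc2cnc(Nc3ccc(NC(=O)C4(C(=O)Nc5ccc(Cl)c(C(F)(F)F)c5)CC4)cc3)nc2n1C1CCCC1`) gives 88.1%. This lies within the scatter of compound 1 (`CN(C)C(=O)c1cc2cnc(Nc3ccc(NC(=O)C4(C(=O)Nc5cccc(F)c5)CC4)cc3)nc2n1C1CCCC1`), which gives 91.8%. Compound 3 stands far beyond the scatter from a compound that lacks the core of compound 1: compound 2 (`Nc1ccc(NC(=O)C2(C(=O)Nc3ccc(F)cc3)CC2)cc1F`) gives 14.6%. Compound 4 (`CN(C)C(=O)c1cc2cnc(Nc3ccc(NC(=O)C4(C(=O)Nc5ccc(C(F)(F)F)cc5)CC4)cc3)nc2n1C1CCCC1`) carries 4-(trifluoromethyl)phenyl in place of 4-chloro-3-(trifluoromethyl)phenyl on an amide-type nitrogen. Among the measured compounds shown here, one measured step bears on this, a change of aryl group on the same nitrogen: a number 3.7 percentage points lower from compound 1 to compound 3 (within the scatter). For the measured compounds named here, no measured pair isolates the present change, so only a small shift, not one beyond the scatter, is expected. The estimated step is a number 2.1 percentage points lower from compound 3 to compound 4 (within the scatter). Compound 4 is expected at 86%, within an estimated range of 74% to 94%.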

Compound 4, percent growth inhibition at one concentration: 87.9%
Estimate against measurement, compound 4: 1.9 percentage points below; low and high end bracket the measured number.
By their numbers in this assay, from the lowest: compound 2; then compounds 4, 3 and 1 (each within the scatter of the next).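

On the amide-type nitrogen, the chlorine of 4-chloro-3-(trifluoromethyl)phenyl can go without a clear loss in this assay, with a number 0.2 percentage points lower from compound 3 to compound 4 (within the scatter) and a number 3.9 percentage points lower from compound 1 to compound 4 (within the scatter). Three different fluorine-bearing aryl groups at this position now give readings that cannot be told apart at this one concentration. Nothing on hand explains this tolerance.

As far as these compounds go, whether it extends to a phenyl carrying an amine or a carboxylic acid, or to a cyclohexyl group in place of the aryl ring, remains open.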